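The source may hold more compounds than are shown below. What is called first, only, known or untested is meant among the compounds shown, and "the series" means these compounds.

Values in a functional assay on the whole organism (strain Wistar) with Rattus norvegicus as the target, read by paw edema; a higher number here means that more compound is needed for the effect, a lower number that less compound is needed:
- compound 1 `CCC(=O)OCc1cc(-n2nc(C(F)(F)F)cc2-c2ccc(OC)c(C)c2)ccc1S(N)(=O)=O`: 10.9 mg/kg
- compound 2 `CCC(=O)NS(=O)(=O)c1ccc(-n2nc(C(F)(F)F)cc2-c2ccc(OC)c(C)c2)cc1CO`: 6.2 mg/kg
- compound 3 `CCC(=O)NS(=O)(=O)c1ccc(-n2nc(C(F)F)cc2-c2ccc(OC)c(C)c2)cc1CO`: 6.3 mg/kg

Compound 2 gives 6.2 mg/kg, and all three numbers lie within the scatter of it, so no order can be drawn among them. The nearest is compound 3, and the furthest is compound 1, also within the scatter.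

Next in the series is compound 4 `CCC(=O)NS(=O)(=O)c1ccc(-n2nc(C(F)(F)F)cc2-c2ccc3c(c2)CCC3)cc1CO`, not yet measured. The change is 2,3-dihydro-1H-inden-5-yl in place of 4-methoxy-3-methylphenyl on an aromatic carbon of the five-membered aromatic ring with 2 nitrogen, next to the ring nitrogen.

For the measured compounds named here, only one measured step bears on this, and only indirectly. a 1.0-fold higher number from compound 2 to compound 3 (0.01 log units; within the scatter) puts hydrogen in place of fluoro on the trifluoromethyl group, at a different place on the molecule. Going by the values given here, no measured compound varies the substituent that changes here, so the size of this step has no direct precedent. The narrow spread of the three values gives no ground for expecting a shift in either direction.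

In this assay the expected result is a 1.0-fold higher number from compound 2 to compound 4 (0.02 log units; within the scatter), an estimated step no larger than the scatter. The range is kept wide for that lack of precedent.

For compound 4 the estimated value is 6.5 mg/kg, with an expected range of 3 mg/kg to 14 mg/kg.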

Compound 4, dose for half-maximal effect: 52 mg/kg
For compound 4 the middle estimate is 8.0-fold (0.90 log units) below the measured one; measured number above the stated range.
By their numbers in this assay, from the lowest: compounds 2, 3 and 1 (each within the scatter of the next); then compound 4.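

In this assay, the aromatic carbon next to the ring nitrogen carries the only single change shown that goes beyond the scatter (an increase of an 8.4-fold higher number from compound 2 to compound 4 (0.92 log units; beyond the scatter)), whereas the change on the trifluoromethyl group stays within it (a 1.0-fold higher number from compound 2 to compound 3 (0.01 log units; within the scatter)). The 4-methoxy-3-methylphenyl and 2,3-dihydro-1H-inden-5-yl groups have the same count of heavy atoms, so that count alone does not set the number at this position; the entering group has no oxygen and no hydrogen-bond acceptor, and it adds a five-membered non-aromatic ring of carbon only. No measurement shown ties the step to any one of these differences.

The compounds shown do not separate the removal of the methoxy group from the closing of the carbon ring, and a phenyl group carrying only the methoxy group or only the methyl group at this place would pull the two apart. Also open, as far as these compounds go, is whether an amine or a hydroxy group on the aromatic ring of the 2,3-dihydro-1H-inden-5-yl group would bring the number back towards that of compound 2.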